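The source may hold more compounds than are shown below. What is called first, only, known or untested is meant among the compounds shown, and "the series" means these compounds.

Values so far in a functional assay on NCI-H460 cells (Homo sapiens) for antiproliferative activity, read by MTT assay, with a stated time of 48 h (a lower number here means a stronger inhibitor, a higher number a weaker inhibitor), for the series
compound 1 `COc1ccc(-c2nc3cccc(-c4cc(OC)c(OC)c(OC)c4)c3o2)cc1` gives 3500 nM
compound 2 `COc1cccc(-c2nc3cccc(-c4cc(OC)c(OC)c(OC)c4)c3o2)c1` gives > 25000 nM as a limit
compound 3 `COc1cc(-c2cccc3nc(-c4ccc(Cl)cc4)oc23)cc(OC)c1OC` gives > 25000 nM as a limit

Compound 3 stands without a number, with only the limit of > 25000 nM in this assay, at which 2 of the 3 values shown sit, as its reading. Compound 4 `COc1cc(-c2cccc3nc(-c4ccc(C)cc4)oc23)cc(OC)c1OC` differs from it by methyl in place of chloro on an aromatic carbon and has methyl in place of chloro, para to a large group.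

Within the data shown here, two measured steps bear on this change. Chloro in place of methoxy gave an at least 7.1-fold higher number from compound 1 to compound 3 (0.85 log units; beyond the scatter) and 3-methoxyphenyl in place of 4-methoxyphenyl gave an at least 7.1-fold higher number from compound 1 to compound 2 (0.85 log units; beyond the scatter) in the same test. From the compounds shown here alone, both lie beyond the scatter, but both end at a limit, so their full size is unknown. Among the measured compounds shown here, no measured compound carries methyl. For the measured compounds named here, compound 1 at 3500 nM is the only number to lean on, so a modest move towards a lower number is expected. A second limit is about as likely, however.

The expected step is an at least 1.6-fold lower number from compound 3 to compound 4 (0.22 log units; that floor lies within the scatter) in this assay on this reading. For compound 4 the estimated value is 15000 nM with an expected range of 4500 nM to 30000 nM as its ends.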

Compound 4, half-maximal inhibitory concentration: 1900 nM
Compound 4: the middle estimate sits 7.9-fold (0.90 log units) above what was measured, and the stated range ends above it.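

Working from this assay, the group para to a large group proves decisive for the 4-chlorophenyl to 4-methylphenyl change: methyl in place of chloro gives an at least 13-fold lower number from compound 3 to compound 4 (1.11 log units; beyond the scatter). Methyl in place of methoxy at this place gives a 1.8-fold lower number from compound 1 to compound 4 (0.27 log units; within the scatter), so a readable value is not tied to methoxy alone, and these two groups are not told apart here. The 4-methylphenyl group in place of 3-methoxyphenyl gives an at least 13-fold lower number from compound 2 to compound 4 (1.11 log units; beyond the scatter), so the outcome also depends on the group's place on the ring, as the 4-methoxyphenyl and 3-methoxyphenyl pair had hinted.

The full size of the steps from compound 2 and compound 3 stays unknown, because each of these compounds has only a limit: the limit of > 25000 nM in this assay, at which 2 of the 4 values shown sit. Also open, from the compounds shown here alone, is whether an ethyl group or an amine, para to a large group, reads with methyl and methoxy or with chloro.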